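A Limit Value and One Swapped Group

A few compounds are considered here, and "the series" means these few. Any claim that something is new, unique, unknown or untested is made for them only; others in the source may bear on it.

Compound 1 `O=C(NNc1ccc(F)cc1)c1ccc(NS(=O)(=O)c2cnc(O)nc2O)cc1` gives > 20000 nM
Compound 2 `O=C(NNc1ccc(F)cc1)c1cccc(NS(=O)(=O)c2cnc(O)nc2O)c1` gives > 20000 nM
Compound 3 `O=C(NNc1ccc(F)cc1)c1ccccc1NS(=O)(=O)c1cnc(O)nc1O` gives > 20000 nM

In a functional assay on OVCAR-3 cells (Homo sapiens) for antiproliferative activity, read by MTT assay, with a stated time of 24 h (a lower number here means a stronger inhibitor, a higher number a weaker inhibitor), compound 1 stands at > 20000 nM, which is a limit of the assay and not a number. It shares that place with the other two measured compounds: the limit of > 20000 nM in this assay, at which 3 of the 3 values shown sit. Going by the values given here, compound 1 therefore offers no exact value to step from.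

Compound 4 `O=C(NNC(=O)c1ccccc1F)c1ccc(NS(=O)(=O)c2cnc(O)nc2O)cc1` keeps the core of compound 1 but carries (2-fluorophenyl)carbonyl in place of 4-fluorophenyl on an amine nitrogen. Among the compounds with values here, no measured pair shows what this swap does, so the data give no direction for a step in this assay, and none beyond the scatter is expected. Within the data shown here, the only guide is compound 1 with its limit of > 20000 nM, and so the assay may well report a limit again. The estimated a number no higher from compound 1 to compound 4 (the limit leaves the size open) is correspondingly small. For compound 4 the expected value is 20000 nM, with an estimated range from 7000 nM to 40000 nM, if a number is obtained at all.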

Compound 4, half-maximal inhibitory concentration: 16000 nM
Compound 4: middle estimate off by 1.3-fold (0.10 log units), on the high side; the measured number falls inside the stated range.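

In this assay, (2-fluorophenyl)carbonyl in place of 4-fluorophenyl on an amine nitrogen gives compound 4 at 16000 nM, the only exact value among the compounds shown, so this place on the shared core can carry a change that yields a real reading. The change amounts to an at least 1.2-fold lower number from compound 1 to compound 4 (0.09 log units; that floor lies within the scatter), which is a floor and does not by itself establish a real gain in strength. No other exact value stands in the series for comparison: the limit of > 20000 nM in this assay, at which 3 of the 4 values shown sit.

This single swap brings in a carbonyl and also changes where the fluorine sits, so the compounds shown cannot say which of the two matters, a question that (4-fluorophenyl)carbonyl on the same nitrogen would address. Plain phenylcarbonyl, with no fluorine at all, would show whether the fluorine is needed.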